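The compounds below may be only part of what the source reports. "The series", "measured", "known", "first", "only" and "open" are said of these compounds alone.

Compound 1 `COc1cc(NC(=O)c2ccc(C)c(C#Cc3cc(-c4cnn(C)c4)cnc3N)c2)cc(OC)c1` and compound 2 `Cc1ccc(C(=O)Nc2cccc(Cl)c2)cc1C#Cc1cc(-c2cnn(C)c2)cnc1N` share the same core and differ only in the ring attached to the amide-type nitrogen. In an ADME assay on RBL-2H3 cells (Rattus norvegicus) for cytotoxicity, read by CCK-8 assay, with a stated time of 24 h (on this read-out lower numbers stand for higher toxicity in this test and higher numbers for lower toxicity in this test), compound 1 gives 397 nM, the higher of the two numbers recorded so far, and compound 2 gives 24.8 nM. Within the data shown here, the one recorded step, a 16-fold lower number from compound 1 to compound 2 (1.20 log units; beyond the scatter), shows that exchanging the ring on that nitrogen can move the read-out far beyond the scatter, and here toward higher toxicity. Compound 3 `Cc1ccc(C(=O)Nc2ccc(C(F)(F)F)cc2)cc1C#Cc1cc(-c2cnn(C)c2)cnc1N` has not yet been measured; it differs from compound 1 in that (4-(trifluoromethyl)phenyl in place of 3,5-dimethoxyphenyl on an amide-type nitrogen). The entering group is not the same as in the recorded step, but the change sits at the same place and, like it, removes the 3,5-dimethoxyphenyl with its two hydrogen-bond acceptors. Because a 16-fold lower number from compound 1 to compound 2 (1.20 log units; beyond the scatter) was large, a move in the same direction is expected for compound 3, though with less certainty given the different entering ring. Compound 3 is therefore estimated to give about 60 nM in this assay, within a range from 15 nM to 250 nM. That estimate would mean an expected step of a 6.6-fold lower number from compound 1 to compound 3 (0.82 log units; beyond the scatter).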

Compound 3, half-maximal cytotoxic concentration: 14 nM
Compound 3: the middle estimate sits 4.3-fold (0.63 log units) above what was measured; the whole stated range lies above it.
By their numbers in this assay, from the lowest: compounds 3 and 2 (each within the scatter of the next); then compound 1.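

In this assay, the exchange of 3,5-dimethoxyphenyl for 4-(trifluoromethyl)phenyl on the amide-type nitrogen brings a 28-fold lower number from compound 1 to compound 3 (1.45 log units; beyond the scatter) and so points the same way as the earlier step, a 16-fold lower number from compound 1 to compound 2 (1.20 log units; beyond the scatter), now with a second, different ring. The two entering rings themselves give a 1.8-fold lower number from compound 2 to compound 3 (0.25 log units; within the scatter), so 3-chlorophenyl and 4-(trifluoromethyl)phenyl cannot be told apart on this read-out, although they carry different groups. Among these three compounds, the higher number therefore belongs only to compound 1, while compounds 2 and 3 both show higher toxicity in this test than compound 1, and no compound goes against this small pattern. Nothing measured here explains the change in toxicity.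

On these data alone, it remains open whether the higher number of compound 1 needs both methoxy groups or whether a ring with only one would keep it. As far as these compounds go, it is also open whether a ring carrying an amine or a carboxylic acid at this place would give a number near that of compound 1 or near those of compounds 2 and 3.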